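Dinitrophenylhydrazone quinolinone: loss of a methyl group

The compounds below may be only part of what the source reports. "The series", "measured", "known", "first", "only" and "open" are said of these compounds alone.

Compound 1 `Cc1ccc2[nH]c(=O)c(/C=N/Nc3ccc([N+](=O)[O-])cc3[N+](=O)[O-])cc2c1`: "not active" (no number reported)
Compound 2 `Cc1ccc2[nH]c(=O)c(/C=N/Nc3ccccc3)cc2c1`: 62400 nM
Compound 3 `O=c1[nH]c2ccccc2cc1/C=N/Nc1ccccc1`: 76500 nM

Three compounds were measured in a functional assay, read by spectrophotometry, with a stated time of 30 min; on this read-out higher numbers stand for weaker inhibition and lower numbers for stronger inhibition. Compound 2 gives 62400 nM and compound 3 gives 76500 nM; the step between them, a 1.2-fold higher number from compound 2 to compound 3 (0.09 log units; within the scatter), is hydrogen in place of methyl on an aromatic carbon. Compound 1 is reported as "not active" (no number reported) in this assay, with no number attached. The difference between the cores of compound 1 and compound 2 is not broken down here. Compound 4 `O=c1[nH]c2ccccc2cc1/C=N/Nc1ccc([N+](=O)[O-])cc1[N+](=O)[O-]` has not been measured; it differs from compound 1 by hydrogen in place of methyl on an aromatic carbon, the same change as from compound 2 to compound 3. Since that change left the number for compound 3 within the scatter of compound 2, compound 4 is expected to stay close to compound 1 in this assay, most likely again without a measurable number. Compound 4 is estimated at 200000 nM, between 80000 nM and 1000000 nM.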

Compound 4, half-maximal inhibitory concentration: 190000 nM
Compound 4: the middle estimate sits 1.1-fold (0.02 log units) above what was measured, within the range that was stated.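

Compound 1 gives "not active" (no number reported) and compound 4 gives 190000 nM, so no step can be read between them. The compounds shown leave open what the methyl group contributes in compound 1. No measurement shown here bears on this result.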